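Cytotoxicity notes: hydrogen in place of chloro on compound 2

The source may report more compounds than this note shows. Statements on the series, on what has been measured and on what is new or still open speak of the compounds shown alone.

In a toxicity assay on THP-1 cells (Homo sapiens) for inhibition (a lower number here means that less compound is tolerated, a higher number that more compound is tolerated), the measured compounds stand as follows:
- compound 1 `Cn1c(-c2ccccc2)cnc1NC(=O)c1ccc(Br)cc1`: > 100000 nM
- compound 2 `Cn1c(-c2ccc(Cl)cc2)cnc1NC(=O)c1ncc[nH]1`: 52000 nM

Among the compounds with values here, compound 2 at 52000 nM holds the only true number so far. Compound 3 `Cn1c(-c2ccccc2)cnc1NC(=O)c1ncc[nH]1` follows from compound 2 through hydrogen in place of chloro on an aromatic carbon with hydrogen in place of chloro on an aromatic carbon. Within the data shown here, no measured pair isolates this change. The expected size is a 1.5-fold higher number from compound 2 to compound 3 (0.19 log units; within the scatter) in this assay toward more compound tolerated, small and close to the scatter. This expectation leans on compound 1, which also carries phenyl and whose > 100000 nM is a limit and not a number. Compound 3 is estimated at 80000 nM with an expected range from 40000 nM to 160000 nM in this read-out.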

Compound 3, half-maximal cytotoxic concentration: > 100000 nM
Compound 3: only a limit was reported (the forecaster's own chance of this, stated with the estimate: 45%); middle value at least 1.2-fold (0.09 log units) from the limit.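

Notes on the 4-chlorophenyl to phenyl change: with the rest of compound 2 held fixed, this position now has its first isolated step in this assay, an at least 1.9-fold higher number from compound 2 to compound 3 (0.28 log units; that floor lies within the scatter). That step is only a floor set by a limit, so it shows no change beyond the scatter, and its true size stays unknown: the limit of > 100000 nM in this assay, at which 2 of the 3 values shown sit.

The step between compound 1 and compound 3 cannot be read. As far as these compounds go, it remains open whether an amine or a methoxy group in place of the chloro would give a true number.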